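Methoxy to Methyl on a Carbonyl, Repeated on a Second Core

A few compounds are considered here, and "the series" means these few. Any claim that something is new, unique, unknown or untested is made for them only; others in the source may bear on it.

Measured in a functional assay on HepG2 cells (Homo sapiens) for antiproliferative activity, read by MTT assay, with a stated time of 72 h; on this read-out higher numbers stand for an effect only at larger amounts of compound and lower numbers for an effect already at smaller amounts:
Compound 1, `COC(=O)c1cc2cc(NCc3cc(NC(=O)c4ccc(CN5CCC(N(C)C)C5)c(C(F)(F)F)c4)ccc3C)cnc2[nH]1`, gives 673 nM.
Compound 2, `CC(=O)c1cc2cc(NCc3cc(NC(=O)c4ccc(CN5CCC(N(C)C)C5)c(C(F)(F)F)c4)ccc3C)cnc2[nH]1`, gives 275 nM.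
Compound 3, `COC(=O)c1cc2cc(CCc3cc(NC(=O)c4ccc(CN5CCC(N(C)C)C5)c(C(F)(F)F)c4)ccc3C)cnc2[nH]1`, reaches only a limit of the assay, > 1000 nM.

Compound 2 differs from compound 1 by one change, (methyl in place of methoxy on a carbonyl carbon). That change brought a 2.4-fold lower number from compound 1 to compound 2 (0.39 log units; beyond the scatter) in this assay. Compound 3 and compound 1 differ in their cores, and that difference is not broken down here. Compound 4, `CC(=O)c1cc2cc(CCc3cc(NC(=O)c4ccc(CN5CCC(N(C)C)C5)c(C(F)(F)F)c4)ccc3C)cnc2[nH]1`, differs from compound 3 by methyl in place of methoxy on a carbonyl carbon, the same change at the same kind of place. Since compound 3 sits at the limit of > 1000 nM in this assay, at which 1 of the 3 values shown sits, only a rough expectation is possible: a step like the earlier one, an at least 1.1-fold lower number from compound 3 to compound 4 (0.04 log units; that floor lies within the scatter), is expected for compound 4. Compound 4 is estimated at 900 nM, between 350 nM and 3000 nM.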

Compound 4, half-maximal effective concentration: 248 nM
Compound 4: the middle estimate sits 3.6-fold (0.56 log units) above what was measured; the whole stated range lies above it.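

In this assay, methyl in place of methoxy on a carbonyl carbon gives a lower number on both cores, and on the second core the change brings an at least 4.0-fold lower number from compound 3 to compound 4 (0.60 log units; beyond the scatter). Compound 3 stands at a limit of the assay, > 1000 nM, so this step has only a floor and no exact size. The direction of the change therefore carries over between these two cores, but whether its size carries over stays unsettled: the same change on two cores in this assay, a 2.4-fold lower number (0.39 log units; beyond the scatter) from compound 1 to compound 2 and an at least 4.0-fold lower number (0.60 log units; beyond the scatter) from compound 3 to compound 4; the limit leaves it open whether they differ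

The compounds shown leave open whether an ethyl group or an amine on the same carbonyl carbon would give a still lower number. They also leave open whether methoxycarbonyl to acetyl would act the same way on any further core.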